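From ethoxy to butoxy: an expected step

The compounds below may be only part of what the source reports. "The series", "measured", "known", "first", "only" and "open" are said of these compounds alone.

Measured compounds:
Compound 1, `CCCCCCCCOc1cc(OC)c(Br)cc1C(C)=O`, gives 38100000 nM in a functional assay, with a stated time of 10 min; on this read-out lower numbers stand for stronger inhibition and higher numbers for weaker inhibition.
Compound 2, `CCCCCCCCCCOc1cc(OC)c(Br)cc1C(C)=O`, gives 29700000 nM.
Compound 3, `CCOc1cc(OC)ccc1C(C)=O`, gives 35300000 nM.

The change from compound 1 to compound 2 is ethyl in place of hydrogen on a saturated chain carbon, eight bonds along the chain from an oxygen on an aromatic ring; it gave a 1.3-fold lower number from compound 1 to compound 2 (0.11 log units; within the scatter). Compound 4, `CCCCOc1cc(OC)ccc1C(C)=O`, is not yet measured; it differs from compound 3 by ethyl in place of hydrogen on a saturated chain carbon, two bonds along the chain from an oxygen on an aromatic ring. This is the same kind of change as that from compound 1 to compound 2, but not the same: there the ethyl enters eight bonds along the chain from an oxygen on an aromatic ring, here two bonds along the chain from an oxygen on an aromatic ring. How the core of compound 3 differs from that of compound 1 is not broken down here. A step of about a 1.2-fold lower number from compound 3 to compound 4 (0.07 log units; within the scatter) is expected because a 1.3-fold lower number from compound 1 to compound 2 (0.11 log units; within the scatter) lay within the scatter. For compound 4 the estimate is 30000000 nM, with a range from 15000000 nM to 60000000 nM.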

Compound 4, half-maximal inhibitory concentration: 57200000 nM
Compound 4: middle estimate off by 1.9-fold (0.28 log units), on the low side, within the range that was stated.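

In this assay the added ethyl gives a 1.6-fold higher number from compound 3 to compound 4 (0.21 log units; within the scatter) and so stays inside the usual scatter. Set beside the earlier step, the change reads the same on both cores as far as these measurements can tell: the same change on two cores in this assay, a 1.3-fold lower number (0.11 log units; within the scatter) from compound 1 to compound 2 and a 1.6-fold higher number (0.21 log units; within the scatter) from compound 3 to compound 4, 2.1-fold (0.32 log units) apart, within the scatter of two such steps. For the compounds shown here, this shows only that the change has no effect that can be told from scatter on either of these two cores, with the ethyl entering at different places along the chain; it does not show that a small real effect is absent, nor that the change would behave alike on any other core.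

The compounds shown leave open whether an amine or a carboxylic acid in place of the added ethyl would give a step beyond the scatter on either core.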